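Changing the aryl on the sulfonyl: little to go on

The source may report more compounds than this note shows. Statements on the series, on what has been measured and on what is new or still open speak of the compounds shown alone.

Compound 1, `COc1ccc(-c2cc(=O)c3c(OC)cc(OC)cc3n2Cc2ccccc2)cc1`: in a functional assay on KOPN-8 cells (Homo sapiens) for antiproliferative activity, with a stated time of 72 h (on this read-out lower numbers stand for an effect already at smaller amounts and higher numbers for an effect only at larger amounts of compound), compound 1 gives > 17300 nM, which is a limit of the assay.
Compound 2, `C=CCNC(=O)n1c(-c2ccc(OC)cc2)cc(=O)c2c(OC)cc(OC)cc21`: in this assay compound 2 gives 12000 nM.
Compound 3, `COc1ccc(-c2cc(=O)c3c(OC)cc(OC)cc3n2S(=O)(=O)c2ccc(C#N)cc2)cc1`: in this assay compound 3 gives > 17200 nM, again a limit of the assay.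

Compound 3 therefore stands at the top of what the assay reports, as the evidence the limit of > 17200 nM in this assay, at which 1 of the 3 values shown sits, shows, and compound 1 sits at a comparable limit (the limit of > 17300 nM in this assay, at which 1 of the 3 values shown sits). Only compound 2 carries a number, and the step of an at least 1.4-fold lower number from compound 1 to compound 2 (0.15 log units; that floor lies within the scatter) reaches no further than the scatter; the step of an at least 1.4-fold higher number from compound 2 to compound 3 (0.15 log units; that floor lies within the scatter) is likewise small, while a step that the two limits leave unreadable from compound 1 to compound 3 cannot be read at all.

Compound 4, `COc1ccc(-c2cc(=O)c3c(OC)cc(OC)cc3n2S(=O)(=O)c2cc(Cl)cc(Cl)c2O)cc1`, is reached from compound 3 by 3,5-dichloro-2-hydroxyphenyl in place of 4-cyanophenyl on a sulfonyl sulfur. Among the compounds with values here, every measured step in this set concerns the group on the aromatic nitrogen; none touches the aryl on the sulfonyl sulfur, so no measured step bears directly on this change. With all three measured values crowded near one limit, the expectation for compound 4 is set by that crowding rather than by any trend: the step of an at least 1.1-fold lower number from compound 3 to compound 4 (0.05 log units; that floor lies within the scatter) is estimated to stay within the scatter. Compound 4 is accordingly expected near 15000 nM in this assay, within a range from 4000 nM to 40000 nM, with a real chance that only a limit is reported.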

Compound 4, half-maximal effective concentration: > 37900 nM
Compound 4: only a limit was reported (the forecaster's own chance of this, stated with the estimate: 55%); middle value at least 2.5-fold (0.40 log units) away from the limit.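

Compound 4 carries only a limit of the assay, and so does compound 3, so the step from compound 3 to compound 4 cannot be read. The compounds shown leave open whether either aryl on the sulfonyl sulfur, 4-cyanophenyl or 3,5-dichloro-2-hydroxyphenyl, differs from the other at all in this assay.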